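Carbamate tail variation in a fluorinated benzyl imidazole series

A few compounds are considered here, and "the series" means these few. Any claim that something is new, unique, unknown or untested is made for them only; others in the source may bear on it.

Measured compounds:
compound 1 `CCCOC(=O)NS(=O)(=O)c1ccccc1-c1ccc(Cn2c(CCC)nc(CC)c2C(=O)OCc2cccc(C(=O)c3ccccc3)c2)c(F)c1`, 10 nM
compound 2 `CCCc1nc(CC)c(C(=O)OCc2ccccc2C(=O)c2ccccc2)n1Cc1ccc(-c2ccccc2S(=O)(=O)NC(=O)OCCc2ccccc2)cc1F`, 0.69 nM

In an assay on isolated protein for binding affinity to Type-2 angiotensin II receptor (Homo sapiens) (a lower number here means a stronger inhibitor, a higher number a weaker inhibitor), compound 2 gives 0.69 nM, the lowest of the two numbers. Compound 1 gives 10 nM, a higher number beyond the scatter. Among the compounds with values here, compounds 1 and 2 differ in more than one place, so no single step is known from them. Compound 3 `CCCCOC(=O)NS(=O)(=O)c1ccccc1-c1ccc(Cn2c(CCC)nc(CC)c2C(=O)OCc2ccccc2C(=O)c2ccccc2)c(F)c1` is compound 2 with ethyl in place of phenyl on a saturated chain carbon, two bonds along the chain from an oxygen next to a carbonyl group. Within the data shown here, no measured pair isolates this change. The step of a 2.9-fold higher number from compound 2 to compound 3 (0.46 log units; beyond the scatter) is expected to be a modest loss, possibly within the scatter. Compound 3 is expected to give 2 nM in this assay, with a range from 0.7 nM to 6 nM.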

Compound 3, half-maximal inhibitory concentration: 0.9 nM
The estimate for compound 3 lay 2.2-fold (0.35 log units) above the measured number; measured number inside the range.
By their numbers in this assay, from the lowest: compounds 2 and 3 (each within the scatter of the next); then compound 1.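

In this assay, within the data shown here, the change from phenyl to ethyl on a saturated chain carbon, two bonds along the chain from an oxygen next to a carbonyl group, gives a 1.3-fold higher number from compound 2 to compound 3 (0.12 log units; within the scatter) and provides the first single-change comparison at this place. The phenethyloxy and butoxy tails therefore cannot be told apart here, so the phenyl is not required on this shared core. No measurement on hand accounts for this result.

From the compounds shown here alone, whether a longer chain or a terminal amine or carboxylic acid would be tolerated at this place remains open. Going by these compounds, compound 1 differs from compound 2 and compound 3 in more than one place, so the source of its higher number also remains open.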